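From methylsulfanyl to methoxy: the step to compound 4

A few compounds are considered here, and "the series" means these few. Any claim that something is new, unique, unknown or untested is made for them only; others in the source may bear on it.

In a physicochemical assay for lipophilicity (on this read-out lower numbers stand for lower lipophilicity and higher numbers for higher lipophilicity), compound 3 `CCOC(=O)/C=C(C)/C=C/CC(C)CCCC(C)(C)SC` stands highest at 6.36, ahead of compound 2 `CCOC(=O)/C=C(C)/C=C/CC(C)CCCC(C)(C)OC(C)=O` at 5.57 and compound 1 `CCOC(=O)/C=C(C)/C=C/CC(C)CCCC(C)(C)O` at 4.65. The next structure is compound 4 `CCOC(=O)/C=C(C)/C=C/CC(C)CCC(OC)C(C)C`: 1-methoxy-2-methylpropyl in place of 2-methyl-2-(methylsulfanyl)propyl on a saturated chain carbon, four bonds along the chain from a double-bonded chain carbon. Here 1-methoxy-2-methylpropyl takes the place of 2-methyl-2-(methylsulfanyl)propyl. Among the compounds with values here, two measured steps bear on this change: a number 1.71 log units higher from compound 1 to compound 3 (beyond the scatter), which is large, and a number 0.79 log units higher from compound 2 to compound 3 (beyond the scatter), which is modest. Both end at the methylsulfanyl compound, and both start from a compound with oxygen on that carbon. Within the data shown here, no measured compound carries methoxy, so this evidence is indirect. A modest fall in this assay is therefore expected, and the estimated step is a number 0.76 log units lower from compound 3 to compound 4 (beyond the scatter). For compound 4 the estimated value is 5.6, with an expected range of 5.1 to 6.1.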

Compound 4, partition coefficient: 5.54
The estimate for compound 4 lay 0.06 log units above the measured number, within the range that was stated.
By their numbers in this assay, from the lowest: compound 1; then compounds 4 and 2 (each within the scatter of the next); then compound 3.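

In this assay the 1-methoxy-2-methylpropyl group sits on both sides of a measured step: down from the methylsulfanyl compound (a number 0.82 log units lower from compound 3 to compound 4 (beyond the scatter)) and up from the hydroxy compound (a number 0.89 log units higher from compound 1 to compound 4 (beyond the scatter)). The change replaces sulfur with oxygen and also rearranges the branching, so these numbers cannot assign the step to either part alone. No measurement given here explains the size of these steps.

Open, on these data alone, is whether 2-methoxy-2-methylpropyl would read like compound 4 on this scale, and where an amine or a carboxylic acid at this place would fall.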